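This account rests on a few compounds, and the source may have more. Where it says the series, first, only, none or still open, it means among the compounds named here.

Two compounds share the same core and differ only in the group attached to a nitrogen on an aromatic ring. In an assay on CHO cells for displacement of a labelled ligand from adenosine receptor A1 (Homo sapiens), read by scintillation counting, with a stated time of 1 h, tested at 1 uM (on this read-out higher numbers stand for more inhibition at the one concentration tested (going by the name of the read-out) and lower numbers for less inhibition), compound 1 `Clc1cccc(-c2cnc(NC3CCCCC3)nc2-c2ccccc2)c1` gives 58%, while compound 2 `Clc1cccc(-c2cnc(NCc3ccccc3)nc2-c2ccccc2)c1` gives 16%. Compound 2 thus stands lowest of the two numbers, with compound 1 the nearer and only neighbour, as the step of a number 42 percentage points lower from compound 1 to compound 2 (beyond the scatter) shows.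

Compound 3 `Clc1cccc(-c2cnc(NCCCc3ccccc3)nc2-c2ccccc2)c1` is the next step from compound 2: phenethyl in place of phenyl on a saturated chain carbon bound to a nitrogen on an aromatic ring. Among the measured compounds shown here, the only measured step that bears on this part of the molecule is the one from compound 1 to compound 2, and it was large, so the group on this nitrogen clearly matters, though nothing measured tells how a longer chain behaves. A modest rise is expected, a number 12 percentage points higher from compound 2 to compound 3 (beyond the scatter), since compound 1 showed that this position can reach 58%. Compound 3 is therefore estimated at 28%, between 5% and 55%.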

Compound 3, a percentage reported as inhibition, at one concentration (the size of the read-out at that concentration, not a potency): 33%
The estimate for compound 3 lay 5 percentage points below the measured number; the range from low to high includes it.
By their numbers in this assay, from the lowest: compound 2; then compound 3; then compound 1.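

Stretching the chain from benzyl to 3-phenylpropyl gives a number 17 percentage points higher from compound 2 to compound 3 (beyond the scatter) in this assay and so shows that chain length alone, with the phenyl ring kept, can move the read-out at this position. The longer chain still does not match cyclohexyl, with a number 25 percentage points lower from compound 1 to compound 3 (beyond the scatter) as the step, so it recovers only part of what the change to benzyl lost. Nothing available here explains why either step occurs.

From the compounds shown here alone, whether a still longer chain, such as phenylbutyl, would raise the number further or lower it remains open. Also open, going by these compounds, is how a saturated ring on a chain, as in cyclohexylmethyl, or a chain ending in an amine would behave on this nitrogen.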